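From sec-butyl to cyclopentyl on a shared core

The source may hold more compounds than are shown below. What is called first, only, known or untested is meant among the compounds shown, and "the series" means these compounds.

In a functional assay on HepG2 cells (Homo sapiens) for antiproliferative activity, read by CCK-8 assay, with a stated time of 72 h (a higher number here means a weaker inhibitor, a lower number a stronger inhibitor), compound 1 `CCC(C)n1cnc2c(NCc3ccc(C(=O)Nc4ccccc4N)cc3)nc(Cl)nc21` gives 2990 nM as the middle of three numbers: compound 2 `Cc1ccc(Nc2nc(Cl)nc3c2ncn3Cc2ccc(C(=O)Nc3ccccc3N)cc2)cc1` stands lower at 860 nM and compound 3 `Nc1ccccc1NC(=O)c1ccc(Cn2cnc3c(NCc4ccccc4)nc(Cl)nc32)cc1` stands higher at 7720 nM as measured. Compound 4 `Nc1ccccc1NC(=O)c1ccc(CNc2nc(Cl)nc3c2ncn3C2CCCC2)cc1` is still unmeasured. It carries cyclopentyl in place of sec-butyl on an aromatic nitrogen compared with compound 1. Going by the values given here, no measured step touches that place. The only one available is a 9.0-fold higher number from compound 2 to compound 3 (0.95 log units; beyond the scatter) with benzyl in place of 4-methylphenyl on a nitrogen on an aromatic ring, a different site. With nothing pointing either way, the expected change in this assay is a 1.2-fold lower number from compound 1 to compound 4 (0.06 log units; within the scatter) and stays within the scatter. Compound 4 is estimated at 2600 nM with an expected range of 1000 nM to 6500 nM for now.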

Compound 4, half-maximal inhibitory concentration: 3430 nM
Compound 4: the middle estimate sits 1.3-fold (0.12 log units) below what was measured; the range from low to high includes it.
By their numbers in this assay, from the lowest: compound 2; then compounds 1 and 4 (each within the scatter of the next); then compound 3.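

In this assay, cyclopentyl in place of sec-butyl on the aromatic nitrogen gives a 1.1-fold higher number from compound 1 to compound 4 (0.06 log units; within the scatter), so the two groups cannot be told apart in this assay. At this position, then, the open branched group and the five-membered carbon ring give values within the usual scatter, even with the added carbon atom. Nothing measured on these compounds bears on this result.

On these data alone, it remains open whether a longer chain such as hexyl, or a chain ending in an amine or a carboxylic acid, would read the same at this nitrogen.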